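Removing a Trifluoromethyl Group Across Two Related Cores

A few compounds are considered here, and "the series" means these few. Any claim that something is new, unique, unknown or untested is made for them only; others in the source may bear on it.

Compound 1 `FC(F)(F)c1ccc(COc2cccc(Nc3ncnc4cc5c(cc34)OCCOCCOCCO5)c2)cc1` has been measured in a functional assay on DU-145 cells (Homo sapiens) for antiproliferative activity, read by MTT assay, with a stated time of 72 h (a lower number here means a stronger inhibitor, a higher number a weaker inhibitor), and gives 2760 nM. Compound 3 `FC(F)(F)c1ccc(COc2ccc(Nc3ncnc4cc5c(cc34)OCCOCCO5)cc2)cc1` carries the same trifluoromethyl-bearing side chain on a different core; the difference between the two cores is not broken down here. In this assay compound 3 reaches only > 100000 nM, which is a limit of the assay and not a number. Compound 2 `c1ccc(COc2ccc(Nc3ncnc4cc5c(cc34)OCCOCCO5)cc2)cc1` differs from compound 3 by hydrogen in place of trifluoromethyl on an aromatic carbon. In this assay compound 2 likewise stops at > 100000 nM, again a limit rather than a number. The step that the two limits leave unreadable from compound 3 to compound 2 therefore cannot be read, because the limit of > 100000 nM in this assay, at which 2 of the 3 values shown sit, covers both of its ends.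

Compound 4 `c1ccc(COc2cccc(Nc3ncnc4cc5c(cc34)OCCOCCOCCO5)c2)cc1` has not yet been measured. Within the data shown here, it differs from compound 1 by hydrogen in place of trifluoromethyl on an aromatic carbon, the same change as the one from compound 3 to compound 2, made around the same kind of place. Among the measured compounds shown here, because the only measured instance of this change sits at the limit of > 100000 nM in this assay, at which 2 of the 3 values shown sit, it offers neither a direction nor a size to carry over. Beside that unreadable step, the step from compound 1 to compound 4 is expected to be a 2.0-fold higher number from compound 1 to compound 4 (0.30 log units; within the scatter), a modest loss that rests on the single number of compound 1 2760 nM and on the lack of any readable guide, so the range is kept wide. Compound 4 is accordingly estimated at 5500 nM, with a range from 1200 nM to 40000 nM.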

Compound 4, half-maximal inhibitory concentration: > 100000 nM
Compound 4 ended at the assay's limit; the forecaster's own chance of this, stated with the estimate: 25%; middle value at least 18-fold (1.25 log units) away from the limit.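

In this assay the replacement of trifluoromethyl by hydrogen on the core of compound 1 gives an at least 36-fold higher number from compound 1 to compound 4 (1.55 log units; beyond the scatter), so on this core the trifluoromethyl-bearing compound is clearly the stronger of the pair. Compound 4 gives > 100000 nM, which is a limit of the assay and not a number. The same replacement on the core of compound 3 cannot be read, so the result does not show whether a loss of this size carries from one core to the other, and it gives no size to transfer to any further core: the limit of > 100000 nM in this assay, at which 3 of the 4 values shown sit.

As far as these compounds go, it stays open whether a methyl group, a chlorine atom, a nitrile or an amine in place of trifluoromethyl, on the same aromatic carbon, would keep a measurable value, as compound 1 does with 2760 nM, or whether only trifluoromethyl does so on this core. Compound 1 and compound 3 differ in more than one place, so the compounds shown also leave open which feature separating them accounts for the measurable value of compound 1.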